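Swapping Ethyl for Methoxycarbonyl on a Shared Amide Core

The source may hold more compounds than are shown below. What is called first, only, known or untested is meant among the compounds shown, and "the series" means these compounds.

Measured so far:
Compound 1, `CC(C)(C)OC(=O)c1cccc(NC(=O)C2CCCN(C(=O)c3cc(C(F)(F)F)cc(C(F)(F)F)c3)C2)c1`: 0%
Compound 2, `CCc1cccc(NC(=O)C2CCCN(C(=O)c3cc(C(F)(F)F)cc(C(F)(F)F)c3)C2)c1`: 0%

Both measured compounds were tested in an ADME assay on PC-3 cells (Homo sapiens) for cytotoxicity, read by WST assay, tested at 100 uM; on this read-out higher numbers stand for more inhibition at the one concentration tested (going by the name of the read-out) and lower numbers for less inhibition. Compound 1 gives 0% in this assay, and compound 2 gives 0%. Going by the values given here, the single measured step, no change at the digits printed from compound 1 to compound 2 (within the scatter), replaced tert-butoxycarbonyl with ethyl on an aromatic carbon and left the read-out unchanged. Compound 2 therefore stands level with compound 1 on the numbers shown, with both at the bottom of the scale.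

The piece now follows the step to compound 3, `COC(=O)c1cccc(NC(=O)C2CCCN(C(=O)c3cc(C(F)(F)F)cc(C(F)(F)F)c3)C2)c1`, which has not yet been measured. The structural change is methoxycarbonyl in place of ethyl on an aromatic carbon. It returns an ester to the position that carried tert-butoxycarbonyl in compound 1, now as methoxycarbonyl. Among the compounds with values here, the one step that bears on it, no change at the digits printed from compound 1 to compound 2 (within the scatter), showed no change beyond the scatter between an ester and an ethyl at this position, so a step of no change at the digits printed from compound 2 to compound 3 (within the scatter) is expected, that is, none beyond the scatter.

Compound 3 is estimated to give 0%, within the range 0% to 10%.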

Compound 3, a percentage reported as inhibition, at one concentration (the size of the read-out at that concentration, not a potency): 0%
The estimate for compound 3 equals the measured number at the digits printed, within the range that was stated.
By their numbers in this assay, from the lowest: compounds 1, 2 and 3 (each within the scatter of the next).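

In this assay, methoxycarbonyl in place of ethyl on the aromatic carbon gave no change at the digits printed from compound 2 to compound 3 (within the scatter), and methyl in place of tert-butyl on the oxygen next to the carbonyl group gave no change at the digits printed from compound 1 to compound 3 (within the scatter). The second step is new in kind: it changes the ester itself and leaves the rest of the molecule alone, so the three compounds now cover a hydrocarbon group and two esters at this one position, and all three read alike at the bottom of the scale. Since a read-out at the bottom of the scale cannot separate these compounds any further, the result shows only that none of the three groups lifts the read-out at the one concentration tested, and nothing available explains this sameness.

On these data alone, it remains open whether any group at this position would lift the read-out from the bottom of the scale, for example a primary amine, a free carboxylic acid or a longer alkyl chain. As far as these compounds go, it also remains open whether a change elsewhere on the shared core, such as a chlorine in place of a trifluoromethyl group, would do so.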